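The source may hold more compounds than are shown below. What is called first, only, known or untested is meant among the compounds shown, and "the series" means these compounds.

Series notes, cytotoxicity. Among the compounds with values here, compound 2 `O=C(NCCNS(=O)(=O)c1ccc(-c2ccccc2O[C@H]2CC[C@@H](O)CC2)s1)Nc1cc(C(F)(F)F)cc(C(F)(F)F)c1` is one of three compounds so far read in an ADME assay on HEK-293T cells (Homo sapiens) for cytotoxicity, read by CCK-8 assay, with a stated time of 48 h; a lower number here means a stronger inhibitor, a higher number a weaker inhibitor. In this assay compound 2 gives 14100 nM. Compound 3 `O=C(NCCNS(=O)(=O)c1ccc(-c2ccccc2O[C@H]2CC[C@@H](O)CC2)s1)Nc1ccc([N+](=O)[O-])cc1` gives 8600 nM in this assay, and the gap between the two lies within the scatter, so neither is put above the other. Compound 1 `O=C(NCCNS(=O)(=O)c1ccc(-c2ccccc2Oc2ccc([N+](=O)[O-])c([N+](=O)[O-])c2)s1)Nc1cc(C(F)(F)F)cc(C(F)(F)F)c1` gives only a limit in this assay, > 50000 nM. Compound 2 therefore holds the higher of the two actual numbers shown.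

The unmeasured compound is compound 4 `Nc1ccc(Oc2ccccc2-c2ccc(S(=O)(=O)NCCNC(=O)Nc3cc(C(F)(F)F)cc(C(F)(F)F)c3)s2)cc1`. Against compound 2 the change is 4-aminophenyl in place of 4-hydroxycyclohexyl on an oxygen on an aromatic ring.

Within the data shown here, the only measured step at the same place is an at least 3.5-fold lower number from compound 1 to compound 2 (0.54 log units; beyond the scatter), where an aromatic ring on that oxygen gave way to the non-aromatic 4-hydroxycyclohexyl; that step rests on (the limit of > 50000 nM in this assay, at which 1 of the 3 values shown sits), so only its lower bound is known. Among the measured compounds shown here, compound 4 reverses the direction of that move, returning an aromatic ring to the oxygen, though as 4-aminophenyl rather than 3,4-dinitrophenyl, and no measured pair separates those two groups. A step back toward a higher number, of modest size at most, is therefore expected in this assay. For compound 4 the expected value in this assay is 22000 nM, within a range from 8000 nM to 50000 nM. The step this expectation implies is a 1.6-fold higher number from compound 2 to compound 4 (0.19 log units; within the scatter). Because the nearest comparison an at least 3.5-fold lower number from compound 1 to compound 2 (0.54 log units; beyond the scatter) is only a bound, a reported limit rather than a number remains possible for compound 4.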

Compound 4, half-maximal inhibitory concentration: > 20000 nM
Compound 4: a limit, no number; the forecaster's own chance of this, stated with the estimate: 30%; the middle value lies beyond the limit too.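

In this assay compound 4 gives only a limit, > 20000 nM, so a second aromatic ring on the oxygen, now 4-aminophenyl rather than the 3,4-dinitrophenyl of compound 1, also ends without a number, while the two compounds carrying 4-hydroxycyclohexyl, compound 2 and compound 3, both give numbers. The change from 4-hydroxycyclohexyl to 4-aminophenyl is read as an at least 1.4-fold higher number from compound 2 to compound 4 (0.15 log units; that floor lies within the scatter), and as that floor lies within the scatter, the result does not set these two compounds apart. The step between 3,4-dinitrophenyl and 4-aminophenyl cannot be read, and the new limit bearing on it is this: the limit of > 20000 nM in this assay, at which 1 of the 4 values shown sits.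

As far as these compounds go, whether compound 4 truly differs from compound 2 beyond the scatter stays open, as does any order between the two aromatic groups on this oxygen. The move from 4-hydroxycyclohexyl to 4-aminophenyl changes the ring and its substituent together, so a 4-aminocyclohexyl group on the same oxygen would be needed to show whether the amine or the aromatic ring goes with the limit.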